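A few compounds are considered here, and "the series" means these few. Any claim that something is new, unique, unknown or untested is made for them only; others in the source may bear on it.

In an assay on CHO-K1 cells for displacement of a labelled ligand from prostaglandin E2 receptor EP1 subtype (Homo sapiens) (a higher number here means a weaker inhibitor, a lower number a stronger inhibitor), compound 1 `Cc1cc(C(=O)NCc2cccnc2)nn1Cc1cc(Cl)ccc1OCc1ccccc1` gives 50.1 nM, the lower of the two values measured, while compound 2 `Cc1cc(C(=O)NN2CCCCC2)nn1Cc1cc(Cl)ccc1OCC(C)C` gives 200 nM; the gap between them lies beyond the scatter, so compound 1 stands as the stronger of the pair. Compound 3 `Cc1cc(NC(=O)OCc2ccccc2)nn1Cc1cc(Cl)ccc1OCc1ccccc1` differs from compound 1 in one place: (benzyloxycarbonyl)amino in place of ((pyridin-3-yl)methyl)carbamoyl on an aromatic carbon. Among the compounds with values here, no measured pair shows this change, so its effect is unknown. The author expects compound 3 to be weaker than compound 1, with a step in this assay of a 6.0-fold higher number from compound 1 to compound 3 (0.78 log units; beyond the scatter) beyond the scatter. Compound 3 is therefore estimated at 300 nM, within a range from 60 nM to 1500 nM.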

Compound 3, half-maximal inhibitory concentration: 79.4 nM
The estimate for compound 3 lay 3.8-fold (0.58 log units) above the measured number; the range from low to high includes it.
By their numbers in this assay, from the lowest: compounds 1 and 3 (each within the scatter of the next); then compound 2.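

In this assay, putting (benzyloxycarbonyl)amino in place of ((pyridin-3-yl)methyl)carbamoyl on this aromatic carbon gives a 1.6-fold higher number from compound 1 to compound 3 (0.20 log units; within the scatter). The position therefore accepts a different link to the outer ring, and a ring of carbon only in place of one with a hetero atom, without a change beyond the scatter. No available evidence explains this result. The compounds shown leave open how these two differences act separately, and whether a plain amine or a carboxylic acid on this carbon would hold the value in this assay.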